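Swapping methoxy for acetyl beside the fluoro group

The compounds below may be only part of what the source reports. "The series", "measured", "known", "first", "only" and "open" are said of these compounds alone.

Compound 1 `COc1cccc(OCC(=O)Nc2cccc(NC(=O)c3ccc(N(C)C)cc3)c2)c1`: > 10000 nM
Compound 2 `COc1ccc(OCC(=O)Nc2cccc(NC(=O)c3ccc(N(C)C)cc3)c2)cc1OC`: > 10000 nM
Compound 3 `COc1ccc(OCC(=O)Nc2cccc(NC(=O)c3ccc(N(C)C)cc3)c2)cc1F`: 1820 nM

In an assay on isolated protein for inhibition of Rho-associated protein kinase 1 (Homo sapiens), read by scintillation counting, radiometric assay and 33P incorporation, with a stated time of 40 min, in the presence of a further agent that is not named here (a lower number here means a stronger inhibitor, a higher number a weaker inhibitor), compound 1 reaches only the limit of the assay, > 10000 nM, not a number. Compound 2 likewise sits at the limit, > 10000 nM. Within the data shown here, compound 3 is the only one with a real number, 1820 nM, and so stands as the sole measured point. Compound 1 and compound 2 both rest at the same limit (the limit of > 10000 nM in this assay, at which 2 of the 3 values shown sit).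

Compound 4 `CC(=O)c1ccc(OCC(=O)Nc2cccc(NC(=O)c3ccc(N(C)C)cc3)c2)cc1F` is not yet measured. It differs from compound 3 by acetyl in place of methoxy on an aromatic carbon. Among the measured compounds shown here, no measured step touches an acetyl group: the steps to compound 3, an at least 5.4-fold lower number from compound 1 to compound 3 (0.73 log units; beyond the scatter) and an at least 5.4-fold lower number from compound 2 to compound 3 (0.73 log units; beyond the scatter), concern fluoro and methoxy alone, and the step that the two limits leave unreadable from compound 1 to compound 2 cannot be read. None of them bears directly on the change at hand. For this assay the expected step from compound 3 to compound 4 is therefore a 1.4-fold higher number from compound 3 to compound 4 (0.14 log units; within the scatter), with no clear direction beyond the scatter. Compound 4 is estimated at 2500 nM in this assay, within a range from 600 nM to 10000 nM.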

Compound 4, half-maximal inhibitory concentration: 445 nM
Estimate against measurement, compound 4: 5.6-fold (0.75 log units) above; measured number outside the range, below it.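

Keeping the fluoro group fixed shows that the group ortho to it has a clear bearing on the result in this assay, since acetyl in place of methoxy gives a 4.1-fold lower number from compound 3 to compound 4 (0.61 log units; beyond the scatter). The whole 4-acetyl-3-fluorophenyl group also stands well apart from the aryl groups of the two inactive-looking compounds, with an at least 22-fold lower number from compound 2 to compound 4 (1.35 log units; beyond the scatter) and an at least 22-fold lower number from compound 1 to compound 4 (1.35 log units; beyond the scatter). These two steps have no upper end because compound 1 and compound 2 rest at a limit of the assay, not at a number: the limit of > 10000 nM in this assay, at which 2 of the 4 values shown sit.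

The compounds shown do not say whether acetyl would give the same gain without the fluoro group, or why acetyl differs from methoxy here. They also leave open how a nitrile, a carboxylic acid or a longer ketone chain such as propanoyl would compare at this position.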